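One Extra Methyl on a Dimethylcarbamoyl Group

The compounds below may be only part of what the source reports. "The series", "measured", "known", "first", "only" and "open" are said of these compounds alone.

For the measured compounds named here, in a physicochemical assay for solubility, measured as kinetic solubility (a lower number here means a less soluble compound, a higher number a more soluble compound), compound 1 `Cc1cnc(NC(=O)c2cc(Oc3cnc(C(=O)N(C)C)cn3)c3cc(C)oc3c2)cn1` gives 176000 nM, the second highest of the three numbers measured so far. Compound 3 `Cc1cnc(NC(=O)c2cc(Oc3ncc(C(=O)N(C)C)cn3)c3cc(C)oc3c2)cn1` gives the highest, 485000 nM, and compound 2 `Cc1cnc(NC(=O)c2cc(Oc3ccc(S(C)(=O)=O)cc3)c3cc(C)oc3c2)cn1` gives the lowest, 3000 nM.

Compound 4 `CCN(C)C(=O)c1cnc(Oc2cc(C(=O)Nc3cnc(C)cn3)cc3oc(C)cc23)cn1` has not yet been measured. It turns the dimethylcarbamoyl group of compound 1 into an ethyl(methyl)carbamoyl group: methyl in place of hydrogen on a saturated chain carbon bound to an amide-type nitrogen. Put simply, this is methyl in place of hydrogen on a saturated chain carbon bound to an amide-type nitrogen.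

Going by the values given here, no two measured compounds differ in one place, so the data offer no direct precedent for this change. The expectation therefore rests on the change being a single added methyl. In this assay, a small move towards a lower number is expected, and it may not go beyond the scatter. The expected size of the step is a 1.4-fold lower number from compound 1 to compound 4 (0.13 log units; within the scatter). For compound 4, the estimated value is 130000 nM, with an expected range from 50000 nM to 320000 nM.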

Compound 4, solubility: 344000 nM
Compound 4: the middle estimate sits 2.6-fold (0.42 log units) below what was measured, outside the stated range (above it).
By their numbers in this assay, from the lowest: compound 2; then compounds 1, 4 and 3 (each within the scatter of the next, the first and the last beyond it).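

In this assay, for the compounds shown here, this is the first pair of compounds that differ in one place, and it gives a 2.0-fold higher number from compound 1 to compound 4 (0.29 log units; within the scatter), so going from dimethylcarbamoyl to ethyl(methyl)carbamoyl produces a step that cannot be told apart from the ordinary spread of repeat measurements. The earlier compounds shown here could not show this: here, a methyl in place of hydrogen on a saturated chain carbon bound to an amide-type nitrogen brings no measurable loss, with compound 4 at 344000 nM. Nothing measured here explains why the number holds.

As far as these compounds go, whether that tolerance extends further out on the same chain remains open, for instance to a longer propyl chain or to a chain ending in an amine or a carboxylic acid. A single pair also cannot say whether the same methyl would behave alike on the other compounds.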